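This account rests on a few compounds, and the source may have more. Where it says the series, first, only, none or still open, it means among the compounds named here.

Compound 1 `CCc1ccc(NC(=O)Nc2cc(C)nc3ccccc23)cc1`: 3300 nM
Compound 2 `COc1ccc(NC(=O)Nc2cc(C)nc3ccccc23)cc1F`: 2700 nM

Both compounds were tested in a physicochemical assay for solubility, at pH 7.4; a higher number here means a more soluble compound, a lower number a less soluble compound. Compound 1 gives 3300 nM and compound 2 gives 2700 nM. For the measured compounds named here, these two numbers lie within the usual scatter of each other, so compound 1 stands level with the only other measured compound.

The next compound to be tested is compound 3 `Cc1cc(NC(=O)Nc2ccc(C(N)=O)cc2)c2ccccc2n1`. It keeps the core of compound 1 but has carbamoyl in place of ethyl on an aromatic carbon, para to a large group (carbamoyl in place of ethyl on an aromatic carbon).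

Going by the values given here, no two measured compounds differ in just one place, so the data offer no direct precedent for this change. Among the compounds with values here, the only guide is that compound 2, with different groups on that ring, still reads 2700 nM, close to compound 1. A small upward step in this assay is therefore expected, one that may not clear the scatter, although a drop cannot be ruled out. The expected change is a 1.5-fold higher number from compound 1 to compound 3 (0.18 log units; within the scatter), and this estimate is uncertain. For compound 3 the estimated value is 5000 nM, with an expected range from 1200 nM to 20000 nM.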

Compound 3, solubility: 900 nM
For compound 3 the middle estimate is 5.6-fold (0.74 log units) above the measured one, and the stated range ends above it.
By their numbers in this assay, from the lowest: compound 3; then compounds 2 and 1 (each within the scatter of the next).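

Carbamoyl in place of ethyl on an aromatic carbon, para to a large group, provides the first comparison here between compounds that differ in one place: in this assay, the swap comes with a 3.7-fold lower number from compound 1 to compound 3 (0.56 log units; beyond the scatter) and lies beyond the usual scatter. The result shows that what sits at this position can change the read-out, and that this change moved it downward even though carbamoyl brings a hydrogen-bond donor and a hydrogen-bond acceptor that ethyl lacks. Nothing measured here explains why the number fell, so the reason remains unknown.

This is a single pair, so it cannot show whether the number follows the hydrogen-bond count, the size of the group or something else, and a primary amine or a carboxylic acid at this position would be needed to begin separating such possibilities. A longer chain in place of ethyl would show how the number behaves when the group grows without gaining a hydrogen-bond donor or acceptor.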